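Methyl in place of methoxy on the aryl ring

This account rests on a few compounds, and the source may have more. Where it says the series, first, only, none or still open, it means among the compounds named here.

Measured compounds:
compound 1 `C=C1C(=O)O[C@H](C)[C@@H]1c1ccc([N+](=O)[O-])cc1` – 21700 nM
compound 2 `C=C1C(=O)O[C@H](C)[C@@H]1c1ccc(OC)cc1` – 4820 nM

For the measured compounds named here, in a functional assay on HL-60 cells (Homo sapiens) for cytotoxicity, read by MTT assay, with a stated time of 48 h (a lower number here means a stronger inhibitor, a higher number a weaker inhibitor), compound 2 gives the lower of the two numbers measured so far. Going by the values given here, its only neighbour is compound 1, and the one measured step is a 4.5-fold lower number from compound 1 to compound 2 (0.65 log units; beyond the scatter), a modest change that concerns a methoxy replacing a nitro group. Compound 3 `C=C1C(=O)O[C@H](C)[C@@H]1c1ccc(C)cc1` has not been measured; it differs from compound 2 by methyl in place of methoxy on an aromatic carbon. Among the compounds with values here, no measured step reports a methoxy-to-methyl exchange, so the single step from compound 1 to compound 2 bears on it only loosely, and nothing in the data marks this exchange as large. Compound 3 is therefore expected to give a number close to that of compound 2, with no step beyond the scatter. The expected step in this assay is a 1.1-fold higher number from compound 2 to compound 3 (0.06 log units; within the scatter). Compound 3 is estimated at 5500 nM, within a range from 2000 nM to 15000 nM.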

Compound 3, half-maximal inhibitory concentration: 5620 nM
For compound 3 the middle estimate is 1.0-fold (0.01 log units) below the measured one; the range from low to high includes it.
By their numbers in this assay, from the lowest: compounds 2 and 3 (each within the scatter of the next); then compound 1.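

In this assay, methyl in place of methoxy on the aromatic carbon gives a 1.2-fold higher number from compound 2 to compound 3 (0.07 log units; within the scatter), so the number holds at this position even with the oxygen of the methoxy gone. Methyl in place of nitro gives a 3.9-fold lower number from compound 1 to compound 3 (0.59 log units; beyond the scatter), which shows that the earlier gain on leaving nitro is not confined to methoxy as the replacing group. Nothing available explains why these two groups read alike or why nitro stands apart.

The compounds shown leave open how an amine, a carboxylic acid, a chlorine atom or a longer alkyl chain would read at this same place. They also leave open whether methoxy and methyl stay this close when the group sits elsewhere on the aromatic ring.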